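A Methyl for a Chloro on the Phenyl Ring

A few compounds are considered here, and "the series" means these few. Any claim that something is new, unique, unknown or untested is made for them only; others in the source may bear on it.

Of the compounds shown here, three sharing one core have been measured in a functional assay on MCF7 cells (Homo sapiens) for cytotoxicity, read by MTT assay, with a stated time of 72 h; a higher number here means a weaker inhibitor, a lower number a stronger inhibitor. Compound 1 `Cc1ccc(-c2ccnc(C(=O)Nc3ccc(Oc4ccnc5[nH]ccc45)cc3)n2)cc1` gives 6410 nM. Compound 2 `O=C(Nc1ccc(Oc2ccnc3[nH]ccc23)cc1)c1nccc(-c2cccc(Cl)c2)n1` gives 10200 nM, and the step of a 1.6-fold higher number from compound 1 to compound 2 (0.20 log units; within the scatter) lies within the scatter. Compound 3 `O=C(Nc1ccc(Oc2ccnc3[nH]ccc23)cc1)c1cc(-c2ccc(Cl)cc2)ncn1` gives 7770 nM, the second highest of the three numbers; compound 1 is its nearest neighbour and compound 2 its furthest, and both sit within the scatter of it.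

Compound 4 `Cc1ccc(-c2cc(C(=O)Nc3ccc(Oc4ccnc5[nH]ccc45)cc3)ncn2)cc1` differs from compound 3 by methyl in place of chloro on an aromatic carbon. Among the compounds with values here, the only measured step that touches on this exchange is a 1.6-fold higher number from compound 1 to compound 2 (0.20 log units; within the scatter), which swaps 4-methylphenyl for 3-chlorophenyl and stays within the scatter; no measured pair exchanges methyl and chloro at the same place. The expected step is therefore a 1.1-fold lower number from compound 3 to compound 4 (0.05 log units; within the scatter), nothing beyond the scatter. Compound 4 is accordingly estimated at 7000 nM in this assay, with a range from 3500 nM to 14000 nM.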

Compound 4, half-maximal inhibitory concentration: 1620 nM
Beside the measured number, compound 4's estimate is 4.3-fold (0.64 log units) above it; the whole stated range lies above it.
By their numbers in this assay, from the lowest: compound 4; then compounds 1, 3 and 2 (each within the scatter of the next).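

In this assay, methyl in place of chloro on an aromatic carbon para to a large group gives a 4.8-fold lower number from compound 3 to compound 4 (0.68 log units; beyond the scatter) and is the only step among these compounds to lie beyond the scatter. The earlier step of a 1.6-fold higher number from compound 1 to compound 2 (0.20 log units; within the scatter) changed the group and its place together and stayed within the scatter, so it gave no sign that exchanging this one heavy atom could separate two compounds on the core of compound 3. Nothing measured here gives a reason for this step.

The compounds shown carry only methyl or chloro on this phenyl ring, so it stays open how a bare hydrogen, a methoxy group or an amine at this place would read. Within the data shown here, also open is whether the exchange would do the same on the core of compound 1, which offers no pair with methyl and chloro at one place.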